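The source may report more compounds than this note shows. Statements on the series, on what has been measured and on what is new or still open speak of the compounds shown alone.

In a functional assay on K562 cells (Homo sapiens) for antiproliferative activity, with a stated time of 72 h (on this read-out lower numbers stand for stronger inhibition and higher numbers for weaker inhibition), compound 1 `OC[C@H]1O[C@@H](n2cnc3c(NCc4ccccc4Br)ncnc32)[C@H](O)[C@@H]1O` gives 10000 nM as a measured number. Compound 2 `Cc1ccc(CNc2ncnc3c2ncn3[C@@H]2O[C@H](CO)[C@@H](O)[C@H]2O)cc1` gives only a limit of the assay, > 166000 nM, and no number. On these data alone, compound 2 therefore stands at that limit, and its true position remains open. Among the measured compounds shown here, the one measured step, an at least 16-fold higher number from compound 1 to compound 2 (1.22 log units; beyond the scatter), came with 4-methylphenyl in place of 2-bromophenyl on a saturated chain carbon bound to a nitrogen on an aromatic ring. Compound 3 `COc1ccccc1CNc1ncnc2c1ncn2[C@@H]1O[C@H](CO)[C@@H](O)[C@H]1O` changes the same place, with 2-methoxyphenyl in place of 4-methylphenyl (2-methoxyphenyl in place of 4-methylphenyl on a saturated chain carbon bound to a nitrogen on an aromatic ring). It thus loses the group found in compound 2 and gains one named like that of compound 1, though methoxy is not bromo. For the measured compounds named here, since the step of an at least 16-fold higher number from compound 1 to compound 2 (1.22 log units; beyond the scatter) is the only guide, a large move towards lower numbers is expected, but its size rests on a single pair and a further limit remains possible. The expected change is an at least 6.6-fold lower number from compound 2 to compound 3 (0.82 log units; beyond the scatter) in this estimate. For compound 3 the estimated value is 25000 nM, with an expected range from 5000 nM to 120000 nM.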

Compound 3, half-maximal inhibitory concentration: 89000 nM
Compound 3: middle estimate off by 3.6-fold (0.55 log units), on the low side, and the stated range covers the measured number.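

Among the compounds shown here, with compound 3 this position has two measured numbers to compare for the first time, as the earlier pair offered only one number and one limit. In this assay, methoxy in place of bromo on an aromatic carbon comes with an 8.9-fold higher number from compound 1 to compound 3 (0.95 log units; beyond the scatter), so 2-methoxyphenyl does not match 2-bromophenyl at this place, although both differ from the 4-methylphenyl of compound 2. The change from 4-methylphenyl to 2-methoxyphenyl gives an at least 1.8-fold lower number from compound 2 to compound 3 (0.27 log units; that floor lies within the scatter), which on its own does not establish a gain, and compound 2 has only a limit of the assay, so the full size of that step stays open: the limit of > 166000 nM in this assay, at which 1 of the 3 values shown sits.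

The compounds shown leave open whether the lower number of compound 1 belongs to bromo itself or would also appear with 2-chlorophenyl or 2-methylphenyl on the same saturated chain carbon. They also leave open how 4-bromophenyl, an unsubstituted phenyl, or a phenyl ring carrying an amine or a carboxylic acid would compare with compound 1 and compound 3.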